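Swapping the benzylic aryl group in a sulfonamide series

The compounds below may be only part of what the source reports. "The series", "measured", "known", "first", "only" and "open" are said of these compounds alone.

Measured so far:
compound 1, `O=S(=O)(NCCCNCc1ccc(Cl)c(C(F)(F)F)c1)c1cc(C(F)(F)F)cc(C(F)(F)F)c1`, 7400 nM
compound 2, `O=S(=O)(NCCCCCCNCc1ccc(Br)cc1)c1ccc2c(c1)OCC2`, 13000 nM

Of the compounds shown here, two have been tested in a functional assay on MIA PaCa-2 cells (Homo sapiens) for inhibition, read by MTT assay, with a stated time of 72 h; a higher number here means a weaker inhibitor of growth, a lower number a stronger inhibitor of growth. Compound 1 gives the lowest of the two numbers, 7400 nM, and compound 2 sits at 13000 nM; the gap between them falls within the usual scatter, so neither can be called the stronger growth inhibitor. Both numbers show weak inhibition of growth.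

Compound 3, `COc1ccccc1CNCCCNS(=O)(=O)c1cc(C(F)(F)F)cc(C(F)(F)F)c1`, has not yet been measured. It differs from compound 1 in one place: 2-methoxyphenyl in place of 4-chloro-3-(trifluoromethyl)phenyl on a saturated chain carbon bound to an amine nitrogen. Going by the values given here, no measured pair shows this kind of change, so there is no directly comparable step to lean on.

Among the compounds with values here, with only two weak starting points and no comparable step, the expectation for compound 3 is a modest move toward a higher number, roughly at the edge of the scatter, giving an estimated step of a 2.0-fold higher number from compound 1 to compound 3 (0.31 log units; beyond the scatter). Compound 3 is therefore expected to give about 15000 nM, with a range from 5000 nM to 45000 nM.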

Compound 3, concentration for 50% growth inhibition: 3100 nM
Compound 3: middle estimate off by 4.8-fold (0.68 log units), on the high side; measured number outside the range, below it.
By their numbers in this assay, from the lowest: compound 3; then compounds 1 and 2 (each within the scatter of the next).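

At this position, on a saturated chain carbon bound to an amine nitrogen, the aryl group can be changed without losing growth inhibition. In this assay, 2-methoxyphenyl in place of 4-chloro-3-(trifluoromethyl)phenyl gives a 2.4-fold lower number from compound 1 to compound 3 (0.38 log units; beyond the scatter), so the chlorine and trifluoromethyl on this ring are not needed for the activity of compound 3. The entering group is also the smaller of the two by heavy atoms, with one hydrogen-bond acceptor where the leaving group has none, but no measurement here separates these differences or links any of them to the step.

On these data alone, it remains open whether a plain phenyl or a 2-ethoxyphenyl group would do as well as 2-methoxyphenyl. Also open, as far as these compounds go, is whether 2-methoxyphenyl would bring a similar step on the core of compound 2.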